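A Methyl Group Tried on Two Related Cores

This account rests on a few compounds, and the source may have more. Where it says the series, first, only, none or still open, it means among the compounds named here.

Compound 1 `CN(C)S(=O)(=O)c1cncc(C#Cc2cc(Cl)ccc2OCC(=O)O)c1`: 37 nM
Compound 2 `CN(C)S(=O)(=O)c1cccc(C#Cc2cc(Cl)ccc2OCC(=O)O)c1`: 14 nM
Compound 3 `Cc1ccc(S(=O)(=O)N(C)C)cc1C#Cc1cc(Cl)ccc1OCC(=O)O`: 5 nM

All three compounds were tested in an assay on CHO cells for displacement of a labelled ligand from prostaglandin D2 receptor 2 (Homo sapiens), read by scintillation counting; a lower number here means a stronger inhibitor, a higher number a weaker inhibitor. Compound 1 and compound 2 share most of their structure but differ in their cores; that difference is not broken down here. What the values show is that compound 1 gives the higher number of the two and stands highest of the three measured compounds.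

Compound 2 and compound 3 differ in one place only: methyl in place of hydrogen on an aromatic carbon. This change gave a 2.8-fold lower number from compound 2 to compound 3 (0.45 log units; beyond the scatter).

Compound 4 `Cc1ncc(S(=O)(=O)N(C)C)cc1C#Cc1cc(Cl)ccc1OCC(=O)O` has not yet been measured. It differs from compound 1 by the same kind of change: methyl in place of hydrogen on an aromatic carbon. The surroundings are not identical, though. In compound 3 the methyl sits on a six-membered aromatic ring of carbon only, whereas in compound 4 it sits on a six-membered aromatic ring with one nitrogen, next to the ring nitrogen. In both cases the methyl is ortho to a large group and para to a dimethylsulfamoyl group.

Starting from compound 1 in this assay, a step of about a 2.6-fold lower number from compound 1 to compound 4 (0.42 log units; beyond the scatter) is expected for compound 4, resting on the size of a 2.8-fold lower number from compound 2 to compound 3 (0.45 log units; beyond the scatter) seen on the other core. The estimate for compound 4 is therefore 14 nM, expected to fall between 6 nM and 35 nM.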

Compound 4, inhibition constant: 41 nM
Compound 4: the middle estimate sits 2.9-fold (0.47 log units) below what was measured; the measured number lies above the stated range.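

In this assay the methyl change on the core of compound 1 gave a 1.1-fold higher number from compound 1 to compound 4 (0.04 log units; within the scatter), so this pair cannot be told apart, and the methyl brought no measurable gain on this core. The same change therefore did not carry over from one core to the other, and the difference between the two steps is larger than repeat measurements alone would explain: the same change on two cores in this assay, a 2.8-fold lower number (0.45 log units; beyond the scatter) from compound 2 to compound 3 and a 1.1-fold higher number (0.04 log units; within the scatter) from compound 1 to compound 4, 3.1-fold (0.49 log units) apart, beyond the scatter of two such steps

Going by these compounds alone, this shows that, for this methyl, the step seen on one core was a poor guide to the step on the other, but it rests on only one pair per core and does not show why the cores differ or whether other changes would carry over.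

The compounds shown leave open whether a different group in the same place, such as ethyl or methoxy, would separate from hydrogen on the core of compound 1. They also leave open whether the methyl would behave the same way on either core if the dimethylsulfamoyl group were replaced by another group, such as a methylsulfonyl group or a primary amide.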